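Moving the chlorine around the phenyl ring

The source may report more compounds than this note shows. Statements on the series, on what has been measured and on what is new or still open speak of the compounds shown alone.

Compound 1 `CC1(C)[C@H]2CC[C@]1(C)N(Cc1cn(-c3ccccc3Cl)nn1)C(=O)C2` carries a 2-chlorophenyl group on an aromatic nitrogen of a five-membered aromatic ring with 3 nitrogen, joined to the shared core. In a functional assay on HepG2 cells (Homo sapiens) for inhibition, read by MTT assay, with a stated time of 24 h (a higher number here means a weaker inhibitor, a lower number a stronger inhibitor), compound 1 gives 60 nM. Among the measured compounds shown here, its only measured companion is compound 2 `CC1(C)[C@H]2CC[C@]1(C)N(Cc1cn(-c3cccc(Br)c3)nn1)C(=O)C2`, which in this assay gives 20 nM; the step between them is a 3.0-fold lower number from compound 1 to compound 2 (0.48 log units; beyond the scatter). Of the two numbers, compound 1 therefore stands as the higher one.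

Compound 3 `CC1(C)[C@H]2CC[C@]1(C)N(Cc1cn(-c3ccc(Cl)cc3)nn1)C(=O)C2` has not yet been measured. 4-chlorophenyl in place of 2-chlorophenyl on an aromatic nitrogen Compound 2 and compound 3 both differ from compound 1 only in the phenyl group on that aromatic nitrogen, though compound 2 also swaps chlorine for bromine. For the measured compounds named here, the one step that bears on this change, a 3.0-fold lower number from compound 1 to compound 2 (0.48 log units; beyond the scatter), was modest but beyond the scatter, so a shift of similar size and direction in this assay seems plausible for compound 3, while a single step remains thin evidence. The expected step is a 2.0-fold lower number from compound 1 to compound 3 (0.30 log units; within the scatter). Compound 3 is thus estimated to give 30 nM, within a range from 10 nM to 90 nM.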

Compound 3, half-maximal inhibitory concentration: 90 nM
Compound 3: middle estimate off by 3.0-fold (0.48 log units), on the low side, and the stated range covers the measured number.
By their numbers in this assay, from the lowest: compound 2; then compounds 1 and 3 (each within the scatter of the next).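

Moving the chlorine from the 2-chlorophenyl group to the 4-chlorophenyl group keeps the same atoms and changes only how they are joined. In this assay this move gives a 1.5-fold higher number from compound 1 to compound 3 (0.18 log units; within the scatter), so the two chlorine placements cannot be told apart in this assay. The 3-bromophenyl group, however, does stand apart from the 4-chlorophenyl group, with a 4.5-fold higher number from compound 2 to compound 3 (0.65 log units; beyond the scatter), which shows that the number can respond to the choice of phenyl group at this aromatic nitrogen, although the lower number of compound 2 is not matched by compound 3. No measurement is available that bears on what lies behind these numbers.

Compound 2 and compound 3 differ in both the halogen and its place on the phenyl ring, so the gap between them cannot be assigned to either change alone, and a 3-chlorophenyl group would be the direct test. From the compounds shown here alone, it also remains open how this assay would respond to a plain phenyl group, or to a phenyl group carrying an amine or a carboxylic acid.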